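The source may hold more compounds than are shown below. What is called first, only, known or untested is meant among the compounds shown, and "the series" means these compounds.

Measured so far in a physicochemical assay for lipophilicity, read by HPLC, measured as octanol-water partition, at pH 7; on this read-out higher numbers stand for higher lipophilicity and lower numbers for lower lipophilicity:
compound 1 `Cc1cc(OC(=O)OCCCCC(CO[N+](=O)[O-])O[N+](=O)[O-])n(-c2ccccc2)n1`: 4.63
compound 2 `Cc1cc(OC(=O)C(C)(C)CCCCO[N+](=O)[O-])n(-c2ccccc2)n1`: 4.3
compound 3 `Cc1cc(OC(=O)CCCCCO[N+](=O)[O-])n(-c2ccccc2)n1`: 3.79

Compound 3 gives the lowest of the three numbers in this assay; compound 2 stands nearest, higher by a gap beyond the scatter, and compound 1 stands furthest, also beyond the scatter. Compound 4 `Cc1cc(OC(=O)CCCC(CO[N+](=O)[O-])O[N+](=O)[O-])n(-c2ccccc2)n1` has not yet been measured. The change from compound 3 to compound 4 is nitrooxy in place of hydrogen on a saturated chain carbon bound to two saturated chain carbons. Within the data shown here, no single-point step between measured compounds covers this change; compound 1 also contains two nitrooxy groups but differs from compound 3 in other respects as well, so its higher value is only a rough pointer. A moderate rise in this assay, beyond the scatter, is expected. Compound 4 is estimated at 4.3, with a range of 3.9 to 4.7. The expected step is a number 0.51 log units higher from compound 3 to compound 4 (beyond the scatter).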

Compound 4, partition coefficient: 3.95
Estimate against measurement, compound 4: 0.35 log units above; the range from low to high includes it.
By their numbers in this assay, from the lowest: compounds 3 and 4 (each within the scatter of the next); then compound 2; then compound 1.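

In this assay, the series now has its first step that differs in one place: nitrooxy in place of hydrogen on a saturated chain carbon bound to two saturated chain carbons gives a number 0.16 log units higher from compound 3 to compound 4 (within the scatter). At this position, a group of 4 heavy atoms thus enters without a shift that can be told from the scatter of this read-out. No measured evidence on hand accounts for this result. On these data alone, whether another group on this carbon, such as an amine or a carboxylic acid, would behave alike stays open. So does the size of the same change on a longer chain.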